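Aryl tail swap on the shared core: chloro to nitro

The source may report more compounds than this note shows. Statements on the series, on what has been measured and on what is new or still open speak of the compounds shown alone.

Measured compounds:
compound 1 `CC(C)=CCC1Cc2c(OCCCNS(=O)(=O)c3ccc(Cl)cc3)cc(=O)n(CCCO)c2CC1(C)C` — 24.7%
compound 2 `CC(C)=CCC1Cc2c(OCCCOc3ccc(Cl)cc3)cc(=O)n(CCCO)c2CC1(C)C` — 22.7%

In a functional assay on PANC-1 cells (Homo sapiens) for inhibition, read by MTT assay, with a stated time of 24 h, tested at 10 uM (a lower number here means less inhibition, a higher number more inhibition at the concentration tested (going by the name of the read-out)), compound 2 gives 22.7%, the lowest of the two numbers; its nearest neighbour is compound 1, and the step of a number 2 percentage points lower from compound 1 to compound 2 (within the scatter) lies within the scatter, so the two compounds cannot be told apart on these data.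

Compound 3 `CC(C)=CCC1Cc2c(OCCCOc3ccc([N+](=O)[O-])cc3)cc(=O)n(CCCO)c2CC1(C)C` is the next step from compound 2. The change is nitro in place of chloro on an aromatic carbon.

Among the compounds with values here, only one measured step exists, a number 2 percentage points lower from compound 1 to compound 2 (within the scatter), and it alters the linker three bonds along the chain from the oxygen on the aromatic ring, not the substituent on the distal six-membered ring. It therefore bears on the present step only loosely, and it was within the scatter. Within the data shown here, no measured pair touches the chloro position itself.

Among the measured compounds shown here, with no step moving the read-out beyond the scatter, the expected step is a number 1.3 percentage points higher from compound 2 to compound 3 (within the scatter), which amounts to no change beyond the scatter. Compound 3 is estimated at 24%, with a range from 12% to 38%.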

Compound 3, a percentage reported as inhibition, at one concentration (the size of the read-out at that concentration, not a potency): 47.5%
Beside the measured number, compound 3's estimate is 23.5 percentage points below it, outside the stated range (above it).
By their numbers in this assay, from the lowest: compounds 2 and 1 (each within the scatter of the next); then compound 3.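

In this assay, within the data shown here, nitro in place of chloro on an aromatic carbon, para to a large group, gives a number 24.8 percentage points higher from compound 2 to compound 3 (beyond the scatter) and is the first change to clear the scatter, so the read-out responds to the substituent at this position, whereas the linker swap gave only a number 2 percentage points lower from compound 1 to compound 2 (within the scatter) as its result. Compound 3 also stands apart from the sulfonylamino compound, with a number 22.8 percentage points higher from compound 1 to compound 3 (beyond the scatter) as the step, which makes compound 3 the highest of the three in this single-concentration read-out, with both of its steps printed as beyond the scatter. Nothing available here explains why nitro gives a higher number than chloro at this position.

The compounds shown leave open whether the rise is particular to nitro or would also appear with a nitrile, an amine or a carboxylic acid at the same place on the ring. They also leave open whether a 4-nitrophenyl group on the sulfonylamino linker of compound 1 would give a step of similar size, and thus whether the nitro change holds across both linkers.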